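The compounds below may be only part of what the source reports. "The series", "measured", "known", "first", "only" and "open" are said of these compounds alone.

Measured so far in a functional assay on HCT-116 cells (Homo sapiens), read by MTT assay, with a stated time of 72 h; on this read-out lower numbers stand for stronger inhibition and higher numbers for weaker inhibition:
- compound 1 `COc1nc(N)nc2c1c(-c1ccsc1)cn2[C@@H]1O[C@H](CO)[C@@H](O)[C@H]1O`: > 20000 nM (a limit)
- compound 2 `Nc1nc2c(c(-c3ccco3)cn2[C@@H]2O[C@H](CO)[C@@H](O)[C@H]2O)c(=O)[nH]1`: > 20000 nM (a limit)
- compound 3 `Nc1nc2c(c(-c3ccoc3)cn2[C@@H]2O[C@H](CO)[C@@H](O)[C@H]2O)c(=O)[nH]1`: 14200 nM

For the measured compounds named here, compound 3 gives the only true number, 14200 nM. The rest of the series shows (the limit of > 20000 nM in this assay, at which 2 of the 3 values shown sit).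

Compound 4 `Nc1nc2c(c(-c3ccccc3)cn2[C@@H]2O[C@H](CO)[C@@H](O)[C@H]2O)c(=O)[nH]1` carries phenyl in place of furan-3-yl on an aromatic carbon. Going by the values given here, one measured step bears on this, the exchange of one aromatic ring for another at that carbon, an at least 1.4-fold lower number from compound 2 to compound 3 (0.14 log units; that floor lies within the scatter). That step gives no sign of a large effect in this assay, so no change beyond the scatter is expected, and a result at the limit remains possible. The estimated step is a 1.1-fold higher number from compound 3 to compound 4 (0.05 log units; within the scatter). Compound 4 is expected at about 16000 nM, within an estimated range of 6000 nM to 40000 nM.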

Compound 4, half-maximal inhibitory concentration: > 20000 nM
Compound 4 was reported as a limit (the forecaster's own chance of this, stated with the estimate: 45%); middle value at least 1.2-fold (0.09 log units) from the limit.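

In this assay, phenyl in place of furan-3-yl on this aromatic carbon gives an at least 1.4-fold higher number from compound 3 to compound 4 (0.14 log units; that floor lies within the scatter), so a six-membered aromatic ring of carbon only is not separated from the five-membered ring here. For the compounds shown here, compound 3 remains the only compound with a true number, and compound 4 is a limit: the limit of > 20000 nM in this assay, at which 3 of the 4 values shown sit. The step between compound 2 and compound 4 cannot be read, as both values are limits. As far as these compounds go, it stays open whether a carboxylic acid or an amine at this carbon would give a number beyond the scatter from compound 3.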